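The source may hold more compounds than are shown below. What is called first, only, known or untested is meant among the compounds shown, and "the series" means these compounds.

Of the compounds shown here, two share one core and have been measured in an assay on isolated protein for inhibition of acyl-CoA desaturase 1 (Mus musculus); a lower number here means a stronger inhibitor, a higher number a weaker inhibitor. Compound 1 `Cc1noc(-c2cccc(NC(=O)N3CCC(Oc4ccccc4Cl)CC3)c2)n1` gives 8 nM in this assay, and compound 2 `CC(C)NC(=O)c1cccc(NC(=O)N2CCC(Oc3ccccc3Cl)CC2)c1` gives 810 nM. Within the data shown here, the one step between them, a 100-fold higher number from compound 1 to compound 2 (2.01 log units; beyond the scatter), is the only measured step so far. On these two numbers compound 2 stands highest, that is, it is the weaker inhibitor of the pair, with compound 1 at a distance well beyond the scatter.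

Compound 3 `CC(C)(C)NC(=O)c1cccc(NC(=O)N2CCC(Oc3ccccc3Cl)CC2)c1` has not been measured. It differs from compound 2 by methyl in place of hydrogen on a saturated chain carbon bound to an amide-type nitrogen and two saturated chain carbons, so that the isopropylcarbamoyl group becomes a (tert-butyl)carbamoyl group. The measured step from compound 1 to compound 2 concerns the exchange of a whole ring for the isopropylcarbamoyl group, not the growth of that group by one carbon, so it bears on this change only loosely. Among the measured compounds shown here, no measured step addresses hydrogen to methyl at this place. For compound 3 the expected change in this assay is therefore a 1.0-fold lower number from compound 2 to compound 3 (0.01 log units; within the scatter), within the scatter, with an estimate of 800 nM and a range from 250 nM to 2600 nM.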

Compound 3, half-maximal inhibitory concentration: > 10000 nM
Compound 3: no number, only a limit; the forecaster's own chance of this, stated with the estimate: 5%; middle value at least 12-fold (1.09 log units) away from the limit.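

In this assay compound 3 gives > 10000 nM and this reading is a limit of the assay, not a number: the limit of > 10000 nM in this assay, at which 1 of the 3 values shown sits. The change from isopropylcarbamoyl to (tert-butyl)carbamoyl gives an at least 12-fold higher number from compound 2 to compound 3 (1.09 log units; beyond the scatter) and so shows what the earlier pair could not: within the amide group itself, one added methyl on the saturated chain carbon bound to the amide-type nitrogen is enough to move the number well beyond the scatter. Set against the 3-methyl-1,2,4-oxadiazol-5-yl group, (tert-butyl)carbamoyl gives an at least 1200-fold higher number from compound 1 to compound 3 (3.09 log units; beyond the scatter) and the exchange of this one group on the shared core therefore spans a very wide range in this assay.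

From the compounds shown here alone, the reading for compound 3 is a limit, so the full size of both new steps stays unknown. Also open, going by these compounds, is whether a methyl, an ethyl or a cyclopropyl group on the amide nitrogen would bring the number nearer to that of compound 1, or whether the amide hydrogen could be replaced as well.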